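Alkyne end group swap on the ester series

This account rests on a few compounds, and the source may have more. Where it says the series, first, only, none or still open, it means among the compounds named here.

Measured so far in a functional assay on HCT-116 cells (Homo sapiens) for cytotoxicity, with a stated time of 3 days; a higher number here means a weaker inhibitor, a lower number a stronger inhibitor:
- compound 1 `CC#Cc1nc(C(=O)OCC)cs1` gives > 40000 nM as a limit
- compound 2 `C=Cc1nc(C(=O)OCC)cs1` gives > 40000 nM as a limit
- compound 3 `c1ccc2[se]cnc2c1` gives > 40000 nM as a limit

Compound 1 has no number, only its limit, and the same holds across the set (the limit of > 40000 nM in this assay, at which 3 of the 3 values shown sit). Compound 4 `CCOC(=O)c1csc(C#Cc2ccccc2)n1` comes from compound 1 by one change, phenyl in place of methyl on a triple-bonded carbon. Within the data shown here, the only measured step (a step that the two limits leave unreadable from compound 1 to compound 2) concerns a different replacement and has no readable size, so it sets no size for this change. Among the measured compounds shown here, no step of definite size and no favoured direction can be expected in this assay from these data. The limit of compound 1 at > 40000 nM is the only anchor for the estimate. For compound 4 the estimated value is 35000 nM with an expected range from 10000 nM to 60000 nM and a reading at the limit is also expected to be likely. The expected step is an at least 1.1-fold lower number from compound 1 to compound 4 (0.05 log units; that floor lies within the scatter) as an estimate only.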

Compound 4, half-maximal inhibitory concentration: > 40000 nM
Compound 4 ended at the assay's limit (the forecaster's own chance of this, stated with the estimate: 65%); middle value at least 1.1-fold (0.05 log units) from the limit.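

No new step can be read: compound 1 and compound 4 both sit at a limit in this assay, and so does every other compound shown: the limit of > 40000 nM in this assay, at which 4 of the 4 values shown sit.

The compounds shown leave open what size the change from methyl to phenyl has, and which structure in this series would give a number rather than a limit in this assay.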